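Moving a Methyl Around the Piperidine Ring

A few compounds are considered here, and "the series" means these few. Any claim that something is new, unique, unknown or untested is made for them only; others in the source may bear on it.

Measured compounds:
compound 1 `COc1cc(Cc2cnc(/N=C3\C(=O)N(CN4CCCCC4C)c4ccc(Cl)cc43)nc2N)cc(OC)c1OC` — > 83.8 ug/mL
compound 2 `CCn1cc(C(=O)O)c(=O)c2cc(F)c(N3CCN(CN4C(=O)/C(=N\c5ncc(Cc6cc(OC)c(OC)c(OC)c6)c(N)n5)c5cc(Cl)ccc54)C(C)C3)c(F)c21` — 18.7 ug/mL

In an ADME assay on CCRF-CEM cells (Homo sapiens) for cytotoxicity, read by MTT assay, with a stated time of 5 days (on this read-out lower numbers stand for higher toxicity in this test and higher numbers for lower toxicity in this test), compound 1 gives > 83.8 ug/mL, which is a limit of the assay rather than a measured number. Compound 2 gives 18.7 ug/mL in this assay. On the numbers shown, compound 1 stands at the limit of > 83.8 ug/mL in this assay, at which 1 of the 2 values shown sits, so only a boundary is known for it, not a point.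

Compound 3 `COc1cc(Cc2cnc(/N=C3\C(=O)N(CN4CCC(C)CC4)c4ccc(Cl)cc43)nc2N)cc(OC)c1OC` differs from compound 1 in one place: 4-methylpiperidin-1-yl in place of 2-methylpiperidin-1-yl on a saturated chain carbon bound to an amide-type nitrogen in a ring. Going by the values given here, no step between two measured compounds is known here, so nothing measured shows how a change of this kind acts on cytotoxicity. The two groups hold the same atoms and ring, only the methyl sits elsewhere on the ring.

The expected step that the limit leaves unreadable from compound 1 to compound 3 is therefore none beyond the usual scatter. Compound 3 is thus estimated at 90 ug/mL, within a range from 40 ug/mL to 200 ug/mL.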

Compound 3, half-maximal cytotoxic concentration: 46.3 ug/mL
Compound 3: middle estimate off by 1.9-fold (0.29 log units), on the high side, within the range that was stated.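

Moving the methyl from 2-methylpiperidin-1-yl to 4-methylpiperidin-1-yl, on the same saturated chain carbon and with the same atoms, gives the first readable step at this position in this assay: an at least 1.8-fold lower number from compound 1 to compound 3 (0.25 log units; that floor lies within the scatter). That step is only a floor, and a floor within the usual scatter does not by itself show that the place of the methyl matters, though the true step could be larger. Going by these compounds, compound 1 has only a limit of the assay, not a number, so the true size of the step stays unknown: the limit of > 83.8 ug/mL in this assay, at which 1 of the 3 values shown sits.

The compounds shown leave open what the methyl itself contributes, since a plain piperidine without it does not appear among them. They also leave open how a morpholine or an open-chain diethylamine would read at this same place.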